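From pyridazin-3-yl to pyridin-2-yl: compound 4

The compounds below may be only part of what the source reports. "The series", "measured", "known", "first", "only" and "open" are said of these compounds alone.

In a physicochemical assay for lipophilicity, read by HPLC, at pH 2 (on this read-out higher numbers stand for higher lipophilicity and lower numbers for lower lipophilicity), compound 1 `CCCC1CCCCN1C(=O)c1cccc(-c2cccc(-n3ncc(C(=O)O)c3C3CC3c3cccnn3)c2)c1` gives 2.9, the highest of three numbers. Compound 2 `CN(CC1CC1)C(=O)c1cccc(-c2cccc(-n3ncc(C(=O)O)c3C3CC3)c2)c1F` gives 2.2, and compound 3 `CN(C)C(=O)c1cccc(-c2cccc(-n3ncc(C(=O)O)c3C3CC3)c2)c1F` gives 1.3. Compound 4 `CCCC1CCCCN1C(=O)c1cccc(-c2cccc(-n3ncc(C(=O)O)c3C3CC3c3ccccn3)c2)c1` differs from compound 1 by pyridin-2-yl in place of pyridazin-3-yl on a saturated ring carbon. Among the measured compounds shown here, the only measured step, a number 0.90 log units lower from compound 2 to compound 3 (beyond the scatter), concerns a saturated chain carbon bound to an amide-type nitrogen, so it shows how far this assay can move but does not cover this exchange. With no measured guide, no shift beyond the scatter is expected, in either direction. The expected step is a number 0.20 log units lower from compound 1 to compound 4 (within the scatter). For compound 4 the estimate is 2.7, with an expected range from 2 to 3.4.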

Compound 4, distribution coefficient: 3.1
Estimate against measurement, compound 4: 0.40 log units below; measured number inside the range.
By their numbers in this assay, from the lowest: compound 3; then compound 2; then compounds 1 and 4 (each within the scatter of the next).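

In this assay, putting pyridin-2-yl in place of pyridazin-3-yl on a saturated ring carbon of the cyclopropyl gives a number 0.20 log units higher from compound 1 to compound 4 (within the scatter). At this position, then, going from a ring with 2 hetero atoms and 2 hydrogen-bond acceptors to one with 1 of each does not shift the number beyond the usual scatter. No supporting data explain why the two compounds read so alike.
Still open, going by these compounds, is how a ring without nitrogen, such as phenyl, or a different kind of group, such as an amine, would read on this cyclopropyl. On these data alone, it is equally open whether the two rings would also read alike with another amide on the shared core.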